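Benzyl to Tert-Butyl on the Triple-Bonded Carbon

The source may report more compounds than this note shows. Statements on the series, on what has been measured and on what is new or still open speak of the compounds shown alone.

Measured so far:
Compound 1 `O=c1[nH]c(=O)n(CCC(CO)CO)cc1-c1cccs1` gives 7800 nM in a functional assay on HeLa cells (Homo sapiens) for antiproliferative activity, read by MTT assay, with a stated time of 72 h; a lower number here means a stronger inhibitor, a higher number a weaker inhibitor.
Compound 2 `CC(=O)OCC(CCn1cc(C#CCc2ccccc2)c(=O)n(C(=O)c2ccccc2)c1=O)COC(C)=O` gives 29900 nM in this assay.
Compound 3 `CCCCCCCCC#Cc1cn(CCC(COC(C)=O)COC(C)=O)c(=O)n(C(=O)c2ccccc2)c1=O` gives 32400 nM in this assay.

Among these three numbers compound 2 stands second highest. Its nearest neighbour is compound 3, reached by the step of a 1.1-fold higher number from compound 2 to compound 3 (0.03 log units; within the scatter), which lies within the scatter, so the two compounds cannot be told apart by these measurements. Furthest from it is compound 1, whose value 7800 nM is lower, and that gap lies beyond the scatter.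

Compound 4 `CC(=O)OCC(CCn1cc(C#CC(C)(C)C)c(=O)n(C(=O)c2ccccc2)c1=O)COC(C)=O` differs from compound 2 by tert-butyl in place of benzyl on a triple-bonded carbon. Among the measured compounds shown here, the only measured step that bears on this change is the one that also swaps the group beyond the triple bond, a 1.1-fold higher number from compound 2 to compound 3 (0.03 log units; within the scatter), where benzyl gave way to a longer saturated chain without any shift beyond the scatter. On that basis the change from benzyl to tert-butyl is expected to give no step beyond the scatter, a 1.0-fold higher number from compound 2 to compound 4 (0.00 log units; within the scatter). Compound 4 is therefore estimated at 30000 nM, with a range from 10000 nM to 90000 nM.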

Compound 4, half-maximal inhibitory concentration: 71500 nM
Compound 4: middle estimate off by 2.4-fold (0.38 log units), on the low side; low and high end bracket the measured number.
By their numbers in this assay, from the lowest: compound 1; then compounds 2 and 3 (each within the scatter of the next); then compound 4.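

In this assay, benzyl and the longer octyl chain could not be told apart on the triple-bonded carbon, so this position could have seemed indifferent to the group it carries. Tert-butyl shows that it is not, with a 2.4-fold higher number from compound 2 to compound 4 (0.38 log units; beyond the scatter) and a 2.2-fold higher number from compound 3 to compound 4 (0.34 log units; beyond the scatter), both modest steps towards a weaker inhibitor. Nothing given here explains why this group behaves differently from the other two.

Still open, as far as these compounds go, is whether a straight butyl chain, with the same count of carbons as tert-butyl, would fall nearer compound 4 or nearer compounds 2 and 3. Also open, from the compounds shown here alone, is whether an amine or a carboxylic acid at the end of such a chain would move the number, and whether these steps would hold without the benzoyl and acetate groups.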